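The compounds below may be only part of what the source reports. "The series", "measured", "known", "first", "only" and "open" are said of these compounds alone.

In an ADME assay on L6 cells (Rattus norvegicus) for cytotoxicity (on this read-out lower numbers stand for stronger inhibition and higher numbers for weaker inhibition), compound 1 (`CC1CCc2ccccc2N1S(=O)(=O)c1ccc([N+](=O)[O-])cc1`) gives 248000 nM and compound 2 (`CC1CCc2ccccc2N1S(=O)(=O)c1cccc([N+](=O)[O-])c1`) gives 187000 nM, two values within the scatter of each other. Compound 3 (`CC1CCc2ccccc2N1S(=O)(=O)c1ccc(Br)cc1`) gives 7360 nM, well under both.

The next step leads from compound 2 to compound 4 (`CC1CCc2ccccc2N1S(=O)(=O)c1ccccc1`), with hydrogen in place of nitro on an aromatic carbon. Within the data shown here, only one measured step bears on this change, and it is large: a 34-fold lower number from compound 1 to compound 3 (1.53 log units; beyond the scatter). Among the measured compounds shown here, it is indirect evidence, since it starts from a different nitro compound and brings in bromo, and no measured compound yet carries hydrogen at this place. For the measured compounds named here, with a 34-fold lower number from compound 1 to compound 3 (1.53 log units; beyond the scatter) as the only guide, a lower number in this assay is expected, but a smaller drop than the bromo step, and the uncertainty is wide. The estimated change is a 3.7-fold lower number from compound 2 to compound 4 (0.57 log units; beyond the scatter). For compound 4 the estimated value is 50000 nM, with an expected range from 15000 nM to 170000 nM.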

Compound 4, half-maximal inhibitory concentration: 70000 nM
The estimate for compound 4 lay 1.4-fold (0.15 log units) below the measured number; measured number inside the range.
By their numbers in this assay, from the lowest: compound 3; then compound 4; then compounds 2 and 1 (each within the scatter of the next).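

In this assay the compound with hydrogen now gives a reference point for the series: hydrogen in place of nitro gives a 2.7-fold lower number from compound 2 to compound 4 (0.43 log units; beyond the scatter) and also a 3.5-fold lower number from compound 1 to compound 4 (0.55 log units; beyond the scatter), so both nitro compounds sit above it. Hydrogen in place of bromo runs the other way, with a 9.5-fold higher number from compound 3 to compound 4 (0.98 log units; beyond the scatter), so the low number of compound 3 goes with the presence of bromo and not only with the loss of nitro. Nothing in the data accounts for these shifts.

As far as these compounds go, whether chloro, fluoro, methoxy or an amine would follow bromo or nitro on this aromatic ring stays open. Also open, from the compounds shown here alone, is whether bromo at the place that carries nitro in compound 2 would match compound 3.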